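Adding a Hydroxy Group to Compound 2

The source may report more compounds than this note shows. Statements on the series, on what has been measured and on what is new or still open speak of the compounds shown alone.

Of the compounds shown here, two sharing one core have been measured in a functional assay on MCF7 cells (Homo sapiens) for cytotoxicity, read by MTT assay, with a stated time of 72 h; on this read-out higher numbers stand for weaker inhibition and lower numbers for stronger inhibition. Compound 1 `CC1(C)O[C@@H](CO)[C@H](Cn2cc(Cn3c4c(c5ccccc53)C(=O)c3c[n+]([O-])c5ccccc5c3C4=O)nn2)O1` gives 690 nM in this assay. Compound 2 `O=C1c2c[n+]([O-])c3ccccc3c2C(=O)c2c1c1ccccc1n2Cc1cn([C@@H]2C[C@H](O)[C@@H](CO)O2)nn1` gives 110 nM, the lowest of the two numbers; the step of a 6.3-fold lower number from compound 1 to compound 2 (0.80 log units; beyond the scatter) lies beyond the scatter, with 4-hydroxy-5-(hydroxymethyl)oxolan-2-yl in place of (5-(hydroxymethyl)-2,2-dimethyl-1,3-dioxolan-4-yl)methyl on an aromatic nitrogen. Compound 3 `O=C1c2c[n+]([O-])c3ccccc3c2C(=O)c2c1c1ccccc1n2Cc1cn([C@H]2O[C@H](CO)[C@@H](O)[C@H]2O)nn1` differs from compound 2 by hydroxy in place of hydrogen on a saturated ring carbon, a hydroxy in place of hydrogen on a saturated ring carbon of the five-membered non-aromatic ring with 1 oxygen. Going by the values given here, only the step from compound 1 to compound 2 touches this part of the structure, and it replaced a much larger group, which gives no direct guide for one added hydroxy. No step beyond the scatter is expected; the estimate for compound 3 is a step of no change at the digits printed from compound 2 to compound 3 (within the scatter), giving 110 nM with a range from 40 nM to 330 nM.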

Compound 3, half-maximal inhibitory concentration: 1490 nM
The estimate for compound 3 lay 14-fold (1.13 log units) below the measured number, outside the stated range (above it).
By their numbers in this assay, from the lowest: compound 2; then compound 1; then compound 3.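

In this assay, this saturated ring carbon proves sensitive to a very small change: adding one hydroxy brings a 14-fold higher number from compound 2 to compound 3 (1.13 log units; beyond the scatter), a large weakening from a single added heavy atom. The same change also reverses the ranking against the dimethyl dioxolane-bearing compound: 4-hydroxy-5-(hydroxymethyl)oxolan-2-yl had the lower number, whereas 3,4-dihydroxy-5-(hydroxymethyl)oxolan-2-yl gives a 2.2-fold higher number from compound 1 to compound 3 (0.33 log units; beyond the scatter). Nothing available here explains the effect of this hydroxy.

The compounds shown leave open whether the weakening is specific to the hydroxy or would also appear with a methoxy, a fluorine or an amine on the same carbon. They also leave open whether a hydroxy with the opposite spatial orientation at this carbon would give a similar number.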